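Phenyl for Ethyl on the Ring Nitrogen

This account rests on a few compounds, and the source may have more. Where it says the series, first, only, none or still open, it means among the compounds named here.

Of the compounds shown here, three sharing one core have been tested in a functional assay on cells (Platelet, Homo sapiens) for inhibition; on this read-out higher numbers stand for weaker inhibition and lower numbers for stronger inhibition. Compound 1 `CCOC(=O)c1ccc(-c2nn(Cc3ccccc3Cl)c3ccccc23)cc1` gives > 10000 nM, which is a limit of the assay rather than a number. Compound 2 `CCOC(=O)c1ccc(-c2nn(Cc3ccc(Cl)cc3)c3ccccc23)cc1` gives > 10000 nM, also a limit. Compound 3 `CCOC(=O)c1ccc(-c2nn(CC)c3ccccc23)cc1` gives > 10000 nM, again a limit. The steps a step that the two limits leave unreadable from compound 1 to compound 2, a step that the two limits leave unreadable from compound 1 to compound 3 and a step that the two limits leave unreadable from compound 2 to compound 3 cannot be sized because of the limit of > 10000 nM in this assay, at which 3 of the 3 values shown sit. Compound 4 `CCOC(=O)c1ccc(-c2nn(-c3ccccc3)c3ccccc23)cc1` differs from compound 3 by phenyl in place of ethyl on an aromatic nitrogen. Within the data shown here, no measured step speaks to this change. With every shown value sitting at the limit, compound 4 is expected at 15000 nM, most likely reported again only as a limit, within a range of 3000 nM to 100000 nM. The expected step that the limit leaves unreadable from compound 3 to compound 4 is therefore not readable against the scatter.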

Compound 4, half-maximal inhibitory concentration: > 10000 nM
Compound 4: a limit, no number; the forecaster's own chance of this, stated with the estimate: 80%; the middle value lies beyond the limit too.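

The steps linking compound 4 with compound 1, compound 2 and compound 3 cannot be read, because each value is only a limit: the limit of > 10000 nM in this assay, at which 4 of the 4 values shown sit. The compounds shown leave open how strongly any of them acts in this assay, and whether the group on the aromatic nitrogen matters.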